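This account rests on a few compounds, and the source may have more. Where it says the series, first, only, none or still open, it means among the compounds named here.

In an ADME assay on MDCKII-LE cells (Canis lupus familiaris) for permeability (on this read-out higher numbers stand for higher permeability and lower numbers for lower permeability), compound 1 (`Cc1cnc(NC(=O)c2cc(Oc3ccc(C(=O)N(C)C)nc3)c3cc(C)oc3c2)cn1`) gives 28.5 10^-6 cm/s and compound 2 (`Cc1cnc(NC(=O)c2cc(Oc3ccc(S(C)(=O)=O)cc3)c3cc(C)oc3c2)cn1`) gives 7.6 10^-6 cm/s as the lower of the two numbers, a gap beyond the scatter. Compound 3 (`Cc1cnc(NC(=O)c2cc(Oc3ccc(C(=O)N(C)C)cc3)c3cc(C)oc3c2)cn1`) differs from compound 2 by dimethylcarbamoyl in place of methylsulfonyl on an aromatic carbon, para to a large group (dimethylcarbamoyl in place of methylsulfonyl on an aromatic carbon). Among the compounds with values here, no measured step covers this change. Compound 1 at 28.5 10^-6 cm/s also carries dimethylcarbamoyl, so a rise in this assay is expected. The estimated step (a 3.3-fold higher number from compound 2 to compound 3 (0.52 log units; beyond the scatter)) is expected to lie beyond the scatter. For compound 3 the estimate is 25 10^-6 cm/s with an expected range of 12 10^-6 cm/s to 45 10^-6 cm/s in this read-out.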

Compound 3, apparent permeability: 5.9 10^-6 cm/s
Compound 3: middle estimate off by 4.2-fold (0.63 log units), on the high side; the measured number lies below the stated range.
By their numbers in this assay, from the lowest: compounds 3 and 2 (each within the scatter of the next); then compound 1.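

In this assay, dimethylcarbamoyl in place of methylsulfonyl on an aromatic carbon, para to a large group, gives a 1.3-fold lower number from compound 2 to compound 3 (0.11 log units; within the scatter) and so leaves the number within the scatter at this position. Dimethylcarbamoyl alone therefore does not bring the higher number, since compound 1 gives 28.5 10^-6 cm/s and compound 3 gives 5.9 10^-6 cm/s with that same group. Nothing at hand accounts for this result.

From the compounds shown here alone, whether an amine or a carboxylic acid at this place would move the number remains open. So does whether the same holds on the ring of compound 1.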